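Methyl added to compound 2: expected step and estimate

A few compounds are considered here, and "the series" means these few. Any claim that something is new, unique, unknown or untested is made for them only; others in the source may bear on it.

Of the compounds shown here, two are measured so far in a functional assay on A549 cells (Homo sapiens) for cytotoxicity, read by CCK-8 assay, with a stated time of 24 h; on this read-out higher numbers stand for weaker inhibition and lower numbers for stronger inhibition. Compound 1 `C/C(=C\c1ccc(-c2ccc(C)cc2)o1)C(N)=O` carries the methyl-bearing aryl ring on a different core from the rest. In this assay compound 1 gives > 50000 nM, which is a limit of the assay and not a number. Compound 2 `C/C(=C\c1nc(-c2ccccc2)cs1)C(N)=O` keeps the same unsaturated amide side chain but has another core and no methyl on its aryl ring. In this assay compound 2 gives > 50000 nM, again a limit rather than a number. Compound 2 thus stands at the limit of > 50000 nM in this assay, at which 2 of the 2 values shown sit, and nothing in the numbers separates it from compound 1.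

Compound 3 `C/C(=C\c1nc(-c2ccc(C)cc2)cs1)C(N)=O` is the next member: methyl in place of hydrogen on an aromatic carbon, the new group sitting on an aromatic carbon of a six-membered aromatic ring of carbon only, para to a large group. Within the data shown here, no measured step of this kind exists. The expected step is a step that the limit leaves unreadable from compound 2 to compound 3, nothing beyond the scatter, because compound 1 also sits at the limit of > 50000 nM in this assay, at which 2 of the 2 values shown sit, while already carrying this methyl on its ring. Compound 3 is therefore expected to give 80000 nM, within 30000 nM to 300000 nM, and most likely to be reported again only as a limit.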

Compound 3, half-maximal inhibitory concentration: > 50000 nM
Compound 3: only a limit was reported (the forecaster's own chance of this, stated with the estimate: 85%); the middle value lies beyond the limit too.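

In this assay compound 3 gives > 50000 nM, a limit of the assay and not a number. Compound 2 also stands at a limit, so no step can be read between compound 2 and compound 3: the limit of > 50000 nM in this assay, at which 3 of the 3 values shown sit.

The compounds shown leave open whether methyl in place of hydrogen on an aromatic carbon changes the result in this assay at all, and how any of them ranks against another.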